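The source may hold more compounds than are shown below. What is called first, only, known or untested is meant among the compounds shown, and "the series" means these compounds.

Series notes on three amides sharing one core. Compound 1 `COc1cccc(OC)c1C(=O)Nc1nnc(-c2ccccc2)s1` carries the unsubstituted phenyl; in a functional assay on the whole organism (integument) for inhibition, with Chilo suppressalis as the target, read by scintillation counting, with a stated time of 72 h, in the presence of a further agent that is not named here (on this read-out higher numbers stand for weaker inhibition and lower numbers for stronger inhibition), compound 1 gives 282 nM. Compound 2 `COc1cccc(OC)c1C(=O)Nc1nnc(-c2ccc(C(C)(C)C)cc2)s1` carries tert-butyl on an aromatic carbon of that ring; in this assay compound 2 gives 525 nM. Compound 3 `COc1cccc(OC)c1C(=O)Nc1nnc(-c2ccc(I)cc2)s1` carries iodo at that carbon; in this assay compound 3 gives 97.7 nM, the lowest of the three numbers, reached by a 2.9-fold lower number from compound 1 to compound 3 (0.46 log units; beyond the scatter) and by a 5.4-fold lower number from compound 2 to compound 3 (0.73 log units; beyond the scatter), both beyond the scatter, whereas a 1.9-fold higher number from compound 1 to compound 2 (0.27 log units; within the scatter) stays within it.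

Compound 4 `COc1cccc(OC)c1C(=O)Nc1nnc(-c2ccc(-c3ccccc3)cc2)s1` differs from compound 3 in one place: phenyl in place of iodo on an aromatic carbon. Within the data shown here, two measured steps bear on this change. The step of a 5.4-fold lower number from compound 2 to compound 3 (0.73 log units; beyond the scatter) compares tert-butyl with iodo at this carbon, and the step of a 1.9-fold higher number from compound 1 to compound 2 (0.27 log units; within the scatter) compares tert-butyl with hydrogen there. Phenyl enters where iodo leaves, and the tert-butyl comparisons are the closest available guide, so a modest move toward higher numbers is expected, a 3.1-fold higher number from compound 3 to compound 4 (0.49 log units; beyond the scatter), probably beyond the scatter yet not reaching the number of compound 2. For compound 4 in this assay the estimate is 300 nM, with a range from 120 nM to 800 nM.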

Compound 4, half-maximal inhibitory concentration: 117 nM
The estimate for compound 4 lay 2.6-fold (0.41 log units) above the measured number; measured number below the stated range.
By their numbers in this assay, from the lowest: compounds 3 and 4 (each within the scatter of the next); then compounds 1 and 2 (each within the scatter of the next).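

In this assay, phenyl and iodo cannot be told apart at this aromatic carbon (a 1.2-fold higher number from compound 3 to compound 4 (0.08 log units; within the scatter)), even though 6 heavy atoms enter where 1 heavy atom leaves, so heavy-atom count alone does not track the number across these two groups. The tert-butyl comparisons therefore do not carry over to phenyl: compound 4 separates from the tert-butyl compound (a 4.5-fold lower number from compound 2 to compound 4 (0.65 log units; beyond the scatter)) and from the unsubstituted phenyl compound (a 2.4-fold lower number from compound 1 to compound 4 (0.38 log units; beyond the scatter)), so iodo and phenyl both give lower numbers than hydrogen, while tert-butyl, in compound 2, goes against that pattern by staying within the scatter of hydrogen. Nothing available here explains why phenyl and tert-butyl part ways at this carbon.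

The compounds shown leave open how fluoro, chloro, an amine, a carboxylic acid or a longer chain at this carbon would compare with iodo and phenyl. They also leave open whether a substituent on the added phenyl ring, such as methoxy or nitrile, would keep the number level with that of compound 4.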